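This account rests on a few compounds, and the source may have more. Where it says the series, first, only, none or still open, it means among the compounds named here.

Compound 1 `Nc1nc(N)c2cc(CSC(=S)N3CCN(c4ccccc4)CC3)ccc2n1` gives 2970 nM
Compound 2 `Nc1nc(N)c2cc(CSC(=S)N3CCN(c4ccccc4Cl)CC3)ccc2n1` gives 3610 nM
Compound 3 `Nc1nc(N)c2cc(CSC(=S)N3CCN(c4ccc(F)cc4)CC3)ccc2n1` gives 2040 nM

All three numbers come from a functional assay on A549 cells (Homo sapiens) for antiproliferative activity, read by MTT assay, with a stated time of 72 h; a lower number here means a stronger inhibitor, a higher number a weaker inhibitor. Compound 1 sits within the usual scatter of both neighbours: the step of a 1.2-fold higher number from compound 1 to compound 2 (0.08 log units; within the scatter) and the step of a 1.5-fold lower number from compound 1 to compound 3 (0.16 log units; within the scatter) are both too small to count, and so is a 1.8-fold lower number from compound 2 to compound 3 (0.25 log units; within the scatter). Compound 4 `CC(=O)c1ccc(N2CCN(C(=S)SCc3ccc4nc(N)nc(N)c4c3)CC2)cc1` differs from compound 1 by acetyl in place of hydrogen on an aromatic carbon. The two steps that bear on this change are those from compound 1 to compound 2 and from compound 1 to compound 3, which also put a small group in place of hydrogen on the same six-membered aromatic ring of carbon only; neither moved the number beyond the scatter. No step beyond the scatter in this assay is therefore expected here either. Compound 4 is expected to give about 2600 nM, somewhere between 1100 nM and 6500 nM, which would mean a 1.1-fold lower number from compound 1 to compound 4 (0.06 log units; within the scatter).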

Compound 4, half-maximal inhibitory concentration: 2550 nM
Compound 4: the middle estimate sits 1.0-fold (0.01 log units) above what was measured; the range from low to high includes it.
By their numbers in this assay, from the lowest: compounds 3, 4, 1 and 2 (each within the scatter of the next).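

In this assay, acetyl on this aromatic carbon, para to a large group, leaves the number within the scatter (a 1.2-fold lower number from compound 1 to compound 4 (0.07 log units; within the scatter)), so tolerance at this ring now extends beyond single halogen atoms to a group with a carbonyl. Compound 4 also cannot be told apart from either halogen compound (a 1.3-fold higher number from compound 3 to compound 4 (0.10 log units; within the scatter); a 1.4-fold lower number from compound 2 to compound 4 (0.15 log units; within the scatter)). No supporting measurement is available to explain this lack of change.

As far as these compounds go, it remains open whether an amine or a carboxylic acid at this position would move the number beyond the scatter. From the compounds shown here alone, whether acetyl on another carbon of this ring would do so also remains open.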